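Furan-2-yl for thiophen-3-yl on the compound 1 core

The compounds below may be only part of what the source reports. "The series", "measured", "known", "first", "only" and "open" are said of these compounds alone.

- compound 1 `c1ccc(-c2cc(-c3ccsc3)cc(-c3ccccn3)n2)nc1` gives 0.000097 ug/mL
- compound 2 `c1ccc(-c2cc(-c3ccsc3)cc(-c3cccnc3)n2)nc1` gives 0.64 ug/mL

Within the data shown here, in a functional assay on A498 cells (Homo sapiens) for antiproliferative activity (a higher number here means a weaker inhibitor of growth, a lower number a stronger inhibitor of growth), compound 1 gives 0.000097 ug/mL as the lower of the two numbers so far. Compound 3 `c1ccc(-c2cc(-c3ccco3)cc(-c3ccccn3)n2)nc1` carries furan-2-yl in place of thiophen-3-yl on an aromatic carbon opposite the ring nitrogen. Among the measured compounds shown here, the only measured step, a 6600-fold higher number from compound 1 to compound 2 (3.82 log units; beyond the scatter) for pyridin-3-yl in place of pyridin-2-yl, lies elsewhere on the core, and it shows only that large steps occur here. For the measured compounds named here, no measured step changes the five-membered ring, so a moderate rise, well short of that step, is expected. The estimated change is a 31-fold higher number from compound 1 to compound 3 (1.49 log units; beyond the scatter) in this reading. For compound 3 the expected value is 0.003 ug/mL within an estimated range of 0.00008 ug/mL to 0.1 ug/mL for now.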

Compound 3, concentration for 50% growth inhibition: 0.000064 ug/mL
The estimate for compound 3 lay 47-fold (1.67 log units) above the measured number; the measured number lies below the stated range.
By their numbers in this assay, from the lowest: compounds 3 and 1 (each within the scatter of the next); then compound 2.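

Opposite the ring nitrogen, furan-2-yl in place of thiophen-3-yl gives a 1.5-fold lower number from compound 1 to compound 3 (0.18 log units; within the scatter), so compound 1 and compound 3 stand within the scatter of each other in this assay. This position therefore accepts this exchange of one five-membered aromatic ring for another, unlike the large step elsewhere on the core, a 6600-fold higher number from compound 1 to compound 2 (3.82 log units; beyond the scatter). Nothing available explains why the two rings read alike.

Open, on these data alone, is whether this position also accepts a group other than a five-membered aromatic ring, such as an amine or a carboxylic acid. Also open, as far as these compounds go, is whether pyridin-3-yl in place of pyridin-2-yl has the same effect with furan-2-yl on the core.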